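Methylcarbamoyl for methylsulfamoyl on the saturated ring carbon

A few compounds are considered here, and "the series" means these few. Any claim that something is new, unique, unknown or untested is made for them only; others in the source may bear on it.

Among the measured compounds shown here, compound 2 `CNS(=O)(=O)[C@@H]1CC[C@@H](Nc2ncc3c(Br)nn(-c4ccc5ncccc5c4)c3n2)C1` holds the only number reported in an assay on isolated protein for inhibition of eIF-2-alpha kinase GCN2 (Homo sapiens); on this read-out lower numbers stand for stronger inhibition and higher numbers for weaker inhibition: in this assay compound 2 gives 43 nM. Compound 1 `COCCNC(=O)CCNc1ncc2c(Br)nn(-c3ccc4ncccc4c3)c2n1` reaches only a limit in this assay, returning > 1000 nM. For the measured compounds named here, the single measured step, an at least 23-fold lower number from compound 1 to compound 2 (1.36 log units; beyond the scatter), is therefore anchored on the limit of > 1000 nM in this assay, at which 1 of the 2 values shown sits, and its true size is open-ended; it also swaps the whole side group on the ring nitrogen at once, so it speaks to that region only loosely.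

Compound 3 `CNC(=O)[C@@H]1CC[C@@H](Nc2ncc3c(Br)nn(-c4ccc5ncccc5c4)c3n2)C1` differs from compound 2 by methylcarbamoyl in place of methylsulfamoyl on a saturated ring carbon. Going by the values given here, no measured step touches that position in isolation; the step from compound 1 to compound 2 is the only evidence that the ring-bearing amine is tolerated. Without a step bearing on this exact exchange, the expectation in this assay is a step of a 1.4-fold higher number from compound 2 to compound 3 (0.14 log units; within the scatter), not clearly beyond the scatter in either direction. Compound 3 is thus estimated at 60 nM, with a range from 15 nM to 250 nM.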

Compound 3, half-maximal inhibitory concentration: 21 nM
For compound 3 the middle estimate is 2.9-fold (0.46 log units) above the measured one; the measured number falls inside the stated range.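

On this saturated ring carbon in this assay, the sulfonamide is not needed for inhibition: exchanging methylsulfamoyl for methylcarbamoyl gives a 2.0-fold lower number from compound 2 to compound 3 (0.31 log units; beyond the scatter), a modest change that keeps the rest of the molecule fixed. Among the compounds shown here, the step of an at least 47-fold lower number from compound 1 to compound 3 (1.67 log units; beyond the scatter) replaces the whole side group on the ring nitrogen at once, so it says less about this carbon and shows only that compound 3, like compound 2, far outperforms the open-chain side group. Compound 1 holds a limit of the assay, not a number, and the true size of this step stays open: the limit of > 1000 nM in this assay, at which 1 of the 3 values shown sits.

From the compounds shown here alone, with a single exchange at this position, it remains open how far the trend extends, for instance to ethylcarbamoyl, an unsubstituted carboxamide or a carboxylic acid. The compounds shown also give no reason for the difference between methylcarbamoyl and methylsulfamoyl, and they do not say whether it would hold with another group in place of the bromine on the shared core.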